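Compound 3: losing a (1-hydroxy-2-methylbutyl)carbonyl group

A few compounds are considered here, and "the series" means these few. Any claim that something is new, unique, unknown or untested is made for them only; others in the source may bear on it.

Compound 1 `CC[C@H](C)[C@@H](O)C(=O)O[C@@H](C(=O)O[C@@H](C(=O)O[C@@H](C(=O)O[C@@H](C(=O)OC[C@@H](O)[C@@H](O)[C@H](O)CO)[C@@H](C)CC)[C@@H](C)CC)[C@@H](C)CC)[C@@H](C)CC`: 29000 nM
Compound 2 `CC[C@H](C)[C@@H](O)C(=O)O[C@@H](C(=O)O[C@@H](C(=O)O[C@@H](C(=O)O[C@@H](C(=O)OC[C@@H](O)[C@@H](O)[C@H](O)[C@H](O)CO)[C@@H](C)CC)[C@@H](C)CC)[C@@H](C)CC)[C@@H](C)CC`: > 53200 nM, a limit of the assay

Going by the values given here, in a functional assay on HepG2 cells (Homo sapiens) for cytotoxicity, read by MTT assay, with a stated time of 24 h (on this read-out higher numbers stand for weaker inhibition and lower numbers for stronger inhibition), compound 1 gives 29000 nM, the only actual number so far. Compound 3 `CC[C@H](C)[C@@H](O)C(=O)O[C@@H](C(=O)O[C@@H](C(=O)O[C@@H](C(=O)OC[C@@H](O)[C@@H](O)[C@H](O)CO)[C@@H](C)CC)[C@@H](C)CC)[C@@H](C)CC` differs from it by hydrogen in place of (1-hydroxy-2-methylbutyl)carbonyl on an oxygen on a saturated carbon: hydrogen stands in place of (1-hydroxy-2-methylbutyl)carbonyl on an oxygen on a saturated carbon. Among the compounds with values here, only one measured step offers any guide: an at least 1.8-fold higher number from compound 1 to compound 2 (0.26 log units; that floor lies within the scatter). That step changes a different group, so no step beyond the scatter is expected in this assay. The expected step is a 1.2-fold higher number from compound 1 to compound 3 (0.08 log units; within the scatter). For compound 3 the estimated value is 35000 nM, with an expected range of 14000 nM to 85000 nM.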

Compound 3, half-maximal inhibitory concentration: > 65700 nM
Compound 3 gave a limit, no number (the forecaster's own chance of this, stated with the estimate: 35%); middle value at least 1.8-fold (0.27 log units) away from the limit.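

In this assay, replacing the (1-hydroxy-2-methylbutyl)carbonyl group on this oxygen with hydrogen gives an at least 2.2-fold higher number from compound 1 to compound 3 (0.35 log units; beyond the scatter). This is the first change shown that clearly weakens the read-out, which the floor of an at least 1.8-fold higher number from compound 1 to compound 2 (0.26 log units; that floor lies within the scatter) could not show. From the compounds shown here alone, compound 3 gives > 65700 nM, which is a limit of the assay, so the true size of the step stays unknown. The compounds shown leave open whether a small acetyl group on this oxygen would behave like the (1-hydroxy-2-methylbutyl)carbonyl group or like hydrogen.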